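The source may report more compounds than this note shows. Statements on the series, on what has been measured and on what is new or still open speak of the compounds shown alone.

Three compounds of a shared core carrying an aryl group on an aromatic nitrogen have been measured. Compound 1 `CC1(C)[C@H]2CC[C@]1(C)N(Cc1cn(-c3ccccc3O)nn1)C(=O)C2` gives 230 nM in a functional assay on A549 cells (Homo sapiens) for inhibition, read by MTT assay, with a stated time of 24 h; a lower number here means a stronger inhibitor, a higher number a weaker inhibitor. Compound 2 `Cc1ccc(-n2cc(CN3C(=O)C[C@@H]4CC[C@@]3(C)C4(C)C)nn2)cc1` gives 400 nM in this assay, and compound 3 `CC1(C)[C@H]2CC[C@]1(C)N(Cc1cn(-c3cccc(Br)c3)nn1)C(=O)C2` gives 90 nM. Compound 2 thus shows the highest of the three numbers; its nearest neighbour is compound 1, with a 1.7-fold higher number from compound 1 to compound 2 (0.24 log units; within the scatter), a gap within the scatter, while the step of a 4.4-fold lower number from compound 2 to compound 3 (0.65 log units; beyond the scatter) lies beyond it.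

Compound 4 `CC1(C)[C@H]2CC[C@]1(C)N(Cc1cn(-c3cccc(F)c3)nn1)C(=O)C2` differs from compound 2 as follows: 3-fluorophenyl in place of 4-methylphenyl on an aromatic nitrogen. Among the compounds with values here, one measured step bears on this change, since the move to a 3-bromophenyl group gave a 4.4-fold lower number from compound 2 to compound 3 (0.65 log units; beyond the scatter), and the related step of a 2.6-fold lower number from compound 1 to compound 3 (0.41 log units; beyond the scatter) points the same way. Within the data shown here, no measured pair compares a 3-fluorophenyl group with a 3-bromophenyl group, so the size of the change for fluorine is uncertain. The account therefore expects compound 4 to give a lower number than compound 2, estimated at 200 nM with a range from 80 nM to 500 nM. That estimate means an expected step of a 2.0-fold lower number from compound 2 to compound 4 (0.30 log units; within the scatter).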

Compound 4, half-maximal inhibitory concentration: 180 nM
For compound 4 the middle estimate is 1.1-fold (0.05 log units) above the measured one, within the range that was stated.
By their numbers in this assay, from the lowest: compounds 3, 4, 1 and 2 (each within the scatter of the next, the first and the last beyond it).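

In this assay the 3-fluorophenyl group on the aromatic nitrogen also clears the scatter against 4-methylphenyl (a 2.2-fold lower number from compound 2 to compound 4 (0.35 log units; beyond the scatter)), so the 3-bromophenyl group is no longer the only replacement of 4-methylphenyl to do so. Within the data shown here, the first direct comparison of the two halogens, fluoro in place of bromo on an aromatic carbon, cannot be told from the scatter (a 2.0-fold higher number from compound 3 to compound 4 (0.30 log units; within the scatter)), and the same holds for 3-fluorophenyl in place of 2-hydroxyphenyl (a 1.3-fold lower number from compound 1 to compound 4 (0.11 log units; within the scatter)). No evidence at hand speaks to the cause of these differences.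

The compounds shown leave open how a chloro group would compare with fluoro and bromo on that aromatic carbon. They also leave open what an amine or a carboxylic acid on the phenyl group, or a longer chain in its place, would give.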